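Moving a trifluoromethyl around the benzyl ring

The compounds below may be only part of what the source reports. "The series", "measured", "known", "first", "only" and "open" are said of these compounds alone.

Compound 1 `Cc1cc(-c2ccccc2)n(/C(N)=N/S(=O)(=O)c2cc(C)c(Cl)cc2SCc2ccc(C(F)(F)F)cc2)n1` is the reference point of this set. In a functional assay on MCF7 cells (Homo sapiens) for cytotoxicity, read by MTT assay, with a stated time of 72 h (on this read-out lower numbers stand for stronger inhibition and higher numbers for weaker inhibition), compound 1 gives 16000 nM. Compound 2 `Cc1cc(S(=O)(=O)/N=C(\N)n2nccc2-c2ccccc2)c(SCc2ccc(C(F)(F)F)cc2)cc1Cl` gives 25000 nM and compound 3 `Cc1cc(S(=O)(=O)/N=C(\N)n2nccc2-c2ccccc2)c(SCc2ccccc2C)cc1Cl` gives 23000 nM; neither number is separated from that of compound 1 by more than the scatter, so the three sit together rather than in any order. The step of a 1.6-fold higher number from compound 1 to compound 2 (0.19 log units; within the scatter) removes a methyl from the shared core; the step of a 1.1-fold lower number from compound 2 to compound 3 (0.04 log units; within the scatter) swaps the aryl group on the saturated chain carbon bound to a sulfur.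

Compound 4 `Cc1cc(-c2ccccc2)n(/C(N)=N/S(=O)(=O)c2cc(C)c(Cl)cc2SCc2ccccc2C(F)(F)F)n1` differs from compound 1 only in that place: 2-(trifluoromethyl)phenyl in place of 4-(trifluoromethyl)phenyl on a saturated chain carbon bound to a sulfur. Going by the values given here, no measured step moves a trifluoromethyl within the same ring, so the nearest guide is the step from compound 2 to compound 3, which exchanged one benzyl aryl for another at the same position and stayed within the scatter. The step from compound 1 to compound 2, at another site, was likewise within the scatter. Taken together, no step beyond the scatter is expected in this assay for compound 4.

The estimate for compound 4 is therefore 17000 nM, with a range of 7000 nM to 40000 nM, which corresponds to an expected step of a 1.1-fold higher number from compound 1 to compound 4 (0.03 log units; within the scatter).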

Compound 4, half-maximal inhibitory concentration: 101000 nM
The estimate for compound 4 lay 5.9-fold (0.77 log units) below the measured number, outside the stated range (above it).
By their numbers in this assay, from the lowest: compounds 1, 3 and 2 (each within the scatter of the next); then compound 4.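

In this assay, exchanging 4-(trifluoromethyl)phenyl for 2-(trifluoromethyl)phenyl on the saturated chain carbon bound to a sulfur gives a 6.3-fold higher number from compound 1 to compound 4 (0.80 log units; beyond the scatter), the only step shown that lies beyond the scatter. The earlier aryl exchange at this position, a 1.1-fold lower number from compound 2 to compound 3 (0.04 log units; within the scatter), gave no sign that the position responds to change, but it was read on the core without the methyl and involved a different pair of groups. Here the group that leaves and the group that enters have the same atoms and the same counts. Nothing shown here explains why the number moves this way.

On these data alone, it remains open whether 2-(trifluoromethyl)phenyl gives a similar number on the core of compound 2, since it appears here only on the core that carries the methyl. Also open, as far as these compounds go, is how this position responds to an unsubstituted phenyl, or to a benzyl ring carrying a methoxy group or a carboxylic acid.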